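Moving the Chlorine Around the Aniline Ring

The source may hold more compounds than are shown below. What is called first, only, known or untested is meant among the compounds shown, and "the series" means these compounds.

In a functional assay on NCI-H1975 cells (Homo sapiens) for inhibition, read by MTT assay, with a stated time of 72 h (on this read-out higher numbers stand for weaker inhibition and lower numbers for stronger inhibition), compound 3 `C=CC(=O)Nc1cccc(NC(=O)CSc2nc(Nc3cccc(Cl)c3)c3ccccc3n2)c1` gives 9460 nM. Within the data shown here, of the three numbers measured so far, this is the low end, though compound 2 `O=C(CSc1nc(Nc2ccccc2)c2ccccc2n1)Nc1ccc(C(F)(F)F)cc1` with 11700 nM and compound 1 `O=C(CSc1nc(Nc2ccccc2)c2ccccc2n1)Nc1cccc([N+](=O)[O-])c1` with 17900 nM both sit within the scatter of it. Compound 4 `C=CC(=O)Nc1cccc(NC(=O)CSc2nc(Nc3ccc(Cl)cc3)c3ccccc3n2)c1` differs from compound 3 by 4-chlorophenyl in place of 3-chlorophenyl on a nitrogen on an aromatic ring. Among the measured compounds shown here, the only single-place step measured, a 1.5-fold lower number from compound 1 to compound 2 (0.18 log units; within the scatter), changes the group on the amide-type nitrogen rather than the nitrogen on the aromatic ring, so it speaks only indirectly to this change. With nothing measured at this position, the change is expected to give a 1.0-fold higher number from compound 3 to compound 4 (0.00 log units; within the scatter), nothing beyond the scatter. Compound 4 is therefore estimated at 9500 nM, with a range from 4000 nM to 22000 nM.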

Compound 4, half-maximal inhibitory concentration: 7580 nM
Beside the measured number, compound 4's estimate is 1.3-fold (0.10 log units) above it, and the stated range covers the measured number.
By their numbers in this assay, from the lowest: compounds 4, 3, 2 and 1 (each within the scatter of the next, the first and the last beyond it).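

In this assay, among these compounds, the swap of 3-chlorophenyl for 4-chlorophenyl on a nitrogen on an aromatic ring gives a 1.2-fold lower number from compound 3 to compound 4 (0.10 log units; within the scatter) and is the first step read directly at this place. It lies within the scatter, so this assay does not tell the two chlorine placements apart. No evidence bearing on this result is available. Going by these compounds, whether an amine or a carboxylic acid in place of the chlorine would give a step beyond the scatter stays open. So does the effect of removing the chlorine while keeping the rest of compound 4 unchanged.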